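The source may hold more compounds than are shown below. What is called first, only, known or untested is meant among the compounds shown, and "the series" means these compounds.

Measured compounds:
Compound 1, `CCN(c1ccc(C#N)c(Cl)c1)c1cc(-c2cncnc2)ccc1C`: in an ADME assay on L02 cells (Homo sapiens) for antiproliferative activity, read by CCK-8 assay, with a stated time of 6 days (a higher number here means a weaker inhibitor, a lower number a stronger inhibitor), compound 1 gives "not determined" (no result reported).
Compound 2, `CCN(c1cccc(-n2ccnc2)c1)c1ccc(C#N)c(Cl)c1`: in this assay compound 2 gives 23200 nM.

For the measured compounds named here, compound 2 therefore stands as the only compound with a number; compound 1 offers nothing to compare against. Compound 3, `CCN(c1ccc(C#N)c(Cl)c1)c1cc(-n2ccnc2)ccc1C`, is not yet measured. The change from compound 2 to compound 3 is methyl in place of hydrogen on an aromatic carbon. Going by the values given here, with no comparable step among measured compounds to lean on, a small step is expected, and the estimated step of a 1.2-fold lower number from compound 2 to compound 3 (0.06 log units; within the scatter) is not expected to exceed the usual scatter in either direction. Compound 3 is therefore expected to give about 20000 nM, likely between 8000 nM and 50000 nM.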

Compound 3, half-maximal inhibitory concentration: 15000 nM
Beside the measured number, compound 3's estimate is 1.3-fold (0.12 log units) above it; the range from low to high includes it.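

In this assay, methyl in place of hydrogen on this aromatic carbon, ortho to a large group and para to the 1H-imidazol-1-yl group, gives a 1.5-fold lower number from compound 2 to compound 3 (0.19 log units; within the scatter) and so the two compounds cannot be told apart. This position therefore accepts one added carbon with no change that can be read beyond the scatter. Nothing on hand explains this outcome. Going by these compounds, whether a longer chain, an amine or a carboxylic acid on this carbon would give a step beyond the scatter stays open.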